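The compounds below may be only part of what the source reports. "The series", "measured", "known", "first", "only" and "open" are said of these compounds alone.

Notes on the series. Compound 1 `COc1ccc(/C=C\c2cc(OC)c(OC)c(OC)c2)cc1OCc1ccc(CN2C[C@H](O)C[C@@H]2C(=O)O)cc1` carries 2-carboxy-4-hydroxypyrrolidin-1-yl on a saturated chain carbon bound to an aromatic carbon. In a functional assay on B16-F10 cells (Mus musculus) for antiproliferative activity, read by CCK-8 assay, with a stated time of 48 h (a higher number here means a weaker inhibitor, a lower number a stronger inhibitor), compound 1 gives only a limit, > 10000 nM. Compound 2 `COc1ccc(/C=C\c2cc(OC)c(OC)c(OC)c2)cc1OCc1ccc(CN2CCCC[C@@H]2C(=O)O)cc1` is reached by a step that the two limits leave unreadable from compound 1 to compound 2. In this assay compound 2 likewise gives only a limit, > 10000 nM. Going by these compounds, both values sit at the limit of > 10000 nM in this assay, at which 2 of the 2 values shown sit, so the size of that step stays unknown.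

Compound 3 `COc1ccc(/C=C\c2cc(OC)c(OC)c(OC)c2)cc1OCc1ccc(CN[C@H](C(=O)O)[C@@H](C)O)cc1` carries the change ((1-carboxy-2-hydroxypropyl)amino in place of 2-carboxy-4-hydroxypyrrolidin-1-yl on a saturated chain carbon bound to an aromatic carbon). Going by the values given here, no measured step bears on this change with a readable size. Among the compounds with values here, the only step out of compound 1, to compound 2, is unreadable. With compound 1 at the limit and compound 2 at the same limit, compound 3 is expected to remain at the limit too, a step that the limit leaves unreadable from compound 1 to compound 3 that would again not be resolved. The estimate for compound 3 in this assay is 15000 nM, with a range from 5000 nM to 50000 nM.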

Compound 3, half-maximal inhibitory concentration: 5400 nM
The estimate for compound 3 lay 2.8-fold (0.44 log units) above the measured number; measured number inside the range.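

In this assay, going by these compounds alone, compound 3, with (1-carboxy-2-hydroxypropyl)amino on a saturated chain carbon bound to an aromatic carbon, gives 5400 nM, the only value shown that is a number and not a limit. Within the data shown here, its steps read an at least 1.8-fold lower number from compound 1 to compound 3 (0.26 log units; that floor lies within the scatter) and an at least 1.8-fold lower number from compound 2 to compound 3 (0.26 log units; that floor lies within the scatter), so both floors stay within the scatter and no gain beyond it is established, though the group without a ring is the first to give a readable value at this position. The two groups with a ring remain limits: the limit of > 10000 nM in this assay, at which 2 of the 3 values shown sit.

Going by these compounds, the true size of both steps stays open, and so does whether the ring, the hydroxy group or both govern the value. Also open, on these data alone, is how a methyl ester in place of the carboxylic acid, or a simple amine without the carboxy group, would read at this position.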